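The source may hold more compounds than are shown below. What is called first, only, known or untested is meant among the compounds shown, and "the series" means these compounds.

Three compounds give numbers in a functional assay on HT-1080 cells (Homo sapiens) for cytotoxicity, read by MTT assay, with a stated time of 72 h; on this read-out lower numbers stand for stronger inhibition and higher numbers for weaker inhibition. Compound 1 `N=C(Nc1cccc(C(F)(F)F)c1)c1cc2c(-c3ccccc3)n[nH]c2cn1` gives 24600 nM in this assay. Among the compounds with values here, compound 2 `CN1CCN(c2ccc(NC(=N)c3cc4cn[nH]c4cn3)cc2)CC1` gives 31300 nM, a number that sits within the usual scatter of the one for compound 1, so the two cannot be ordered. Compound 3 `N=C(Nc1ccccc1)c1cc2c(-c3ccccc3)n[nH]c2c(NC2CCCCC2)n1` gives 850 nM, which stands well apart from both of them and beyond the scatter, so compound 1 holds the second highest of the three numbers, with compound 3 far below it.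

Compound 4 `Cn1nc(-c2ccccc2)c2cc(C(=N)Nc3cccc(C(F)(F)F)c3)ncc21` has not been measured in this assay. It differs from compound 1 only by methyl in place of hydrogen on an aromatic nitrogen of the shared core. Within the data shown here, no measured pair in this set shows what such a change does, and the record gives no guide for its direction. The expected step from compound 1 to compound 4 is therefore a 1.4-fold higher number from compound 1 to compound 4 (0.15 log units; within the scatter), small and uncertain, leaning towards a slightly higher number. Compound 4 is accordingly estimated at 35000 nM, with a range from 12000 nM to 100000 nM.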

Compound 4, half-maximal inhibitory concentration: 17800 nM
Beside the measured number, compound 4's estimate is 2.0-fold (0.29 log units) above it; the measured number falls inside the stated range.
By their numbers in this assay, from the lowest: compound 3; then compounds 4, 1 and 2 (each within the scatter of the next).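

In this assay, the change gives a 1.4-fold lower number from compound 1 to compound 4 (0.14 log units; within the scatter) and so compound 1 and compound 4 cannot be ordered. Within the data shown here, this is the first pair here that differs in one place, and it shows that methyl can stand in place of hydrogen on this aromatic nitrogen of the five-membered ring without a step beyond the scatter. Nothing in the record bears on why the number behaves this way.

As far as these compounds go, whether a longer chain or a chain ending in an amine or a carboxylic acid on this nitrogen would also stay within the scatter remains open. It also remains open whether methyl on this nitrogen would leave the far lower number of compound 3 850 nM similarly undisturbed, since the one step shown starts from compound 1.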